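Methyl on the Benzoyl Ring in Diiodosalicyl Hydrazides

The compounds below may be only part of what the source reports. "The series", "measured", "known", "first", "only" and "open" are said of these compounds alone.

Compound 1 `O=C(N/N=C/c1cc(I)cc(I)c1O)c1ccccc1` and compound 2 `Cc1ccc(C(=O)N/N=C/c2cc(I)cc(I)c2O)cc1` share a hydrazone core, while compound 3 `O=C(NNC(=O)c1cc(I)cc(I)c1O)c1ccccc1` and compound 4 `Cc1ccc(C(=O)NNC(=O)c2cc(I)cc(I)c2O)cc1` carry a diacylhydrazine; the difference between the two cores is not broken down here. In a functional assay on HepG2 cells (Homo sapiens) for cytotoxicity, with a stated time of 24 h (a lower number here means a stronger inhibitor, a higher number a weaker inhibitor), compound 1 gives only a limit, > 50000 nM. In this assay compound 2 likewise gives only a limit, > 25000 nM. The change between them methyl in place of hydrogen on an aromatic carbon therefore makes a step that the two limits leave unreadable from compound 1 to compound 2 that cannot be sized. In this assay compound 3 gives 98000 nM. The same change is made from compound 3 to compound 4 (methyl in place of hydrogen on an aromatic carbon). With compound 3 at 98000 nM and no readable size for the earlier step, compound 4 is expected to stay about as weak, a step of a 1.1-fold lower number from compound 3 to compound 4 (0.04 log units; within the scatter). Compound 4 is thus estimated at 90000 nM.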

Compound 4, half-maximal inhibitory concentration: 86400 nM
The estimate for compound 4 lay 1.0-fold (0.02 log units) above the measured number; the measured number falls inside the stated range.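

On the diacylhydrazine core in this assay, methyl in place of hydrogen on an aromatic carbon gives a 1.1-fold lower number from compound 3 to compound 4 (0.05 log units; within the scatter), so on this core the change has no effect that can be told from the scatter. The step on the hydrazone core cannot be read, since both of its ends are limits and not numbers, and it offers no size to compare. The result therefore describes the change on one core only and does not show that it carries over from one core to the other, and no measured property shown here accounts for the result.

The compounds shown leave open how an amine, a carboxylic acid or a longer chain in place of the methyl would read in this assay on either core. They also leave open the size of the change on the hydrazone core.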